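The compounds below may be only part of what the source reports. "The series", "measured", "known", "first", "only" and "open" are said of these compounds alone.

Compound 2 `NC(=O)c1ccc2c(c1)nc(Nc1ccc(S(N)(=O)=O)cc1)n2Cc1nc2ccccc2s1` was tested in an assay on isolated protein for inhibition of kinesin heavy chain isoform 5A (Homo sapiens) (on this read-out lower numbers stand for stronger inhibition and higher numbers for weaker inhibition), where compound 2 reaches only a limit of the assay at > 50000 nM. Its neighbour compound 1 `NC(=O)c1ccc2c(c1)nc(Nc1ccc(S(N)(=O)=O)cc1)n2Cc1ccccn1` also stands at a limit, giving > 50000 nM in this assay. The step that the two limits leave unreadable from compound 1 to compound 2 is therefore unreadable, since (the limit of > 50000 nM in this assay, at which 2 of the 2 values shown sit). From the compounds shown here alone, compound 3 `NC(=O)c1ccc2c(c1)nc(Nc1ccc(S(N)(=O)=O)cc1)n2Cc1csc2ccccc12` is untested; it differs from compound 2 by 1-benzothiophen-3-yl in place of 1,3-benzothiazol-2-yl on a saturated chain carbon bound to an aromatic nitrogen. Within the data shown here, no measured step bears on this change: the only step available, from compound 1 to compound 2, cannot be read, and both values on record are limits. Among the measured compounds shown here, with two limits as the sole guide, the expected step is a number no higher from compound 2 to compound 3 (the limit leaves the size open), no change beyond the scatter. The expectation is that compound 3 will again reach the limit of this assay. Compound 3 is therefore estimated at 50000 nM, within a range from 20000 nM to 200000 nM.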

Compound 3, half-maximal inhibitory concentration: > 50000 nM
Compound 3 gave a limit, no number; the forecaster's own chance of this, stated with the estimate: 85%; the middle value lies on the limit itself.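

With compound 3 in hand, no step among compound 1, compound 2 and compound 3 can be read in this assay, because all three values are limits: the limit of > 50000 nM in this assay, at which 3 of the 3 values shown sit.

The compounds shown leave open how strongly each one inhibits, and whether any group in this place would give a readable number in this assay.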